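A Methyl Step Repeated at the Edge of the Assay

A few compounds are considered here, and "the series" means these few. Any claim that something is new, unique, unknown or untested is made for them only; others in the source may bear on it.

In a functional assay on PANC-1 cells (Homo sapiens) for inhibition, read by MTT assay, with a stated time of 72 h (on this read-out lower numbers stand for stronger inhibition and higher numbers for weaker inhibition), compound 2 `Cc1ccc2cccc(NC(=O)c3cnccn3)c2n1` gives only a limit, > 10000 nM. Compound 1 `Cc1cnc(C(=O)Nc2cccc3ccc(C)nc23)cn1` likewise gives a limit, > 10000 nM. The change from compound 2 to compound 1 is methyl in place of hydrogen on an aromatic carbon, and its step that the two limits leave unreadable from compound 2 to compound 1 cannot be read, since (the limit of > 10000 nM in this assay, at which 2 of the 3 values shown sit). Compound 3 `CC(C)(C)OC(=O)NCCOc1cc(NC(=O)c2cnccn2)c2ncccc2c1` carries a longer side chain on the shared core; how its core differs from that of compound 2 is not broken down here. Among the measured compounds shown here, compound 3 is the one member with a number, giving 9500 nM in this assay.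

Compound 4 `Cc1cnc(C(=O)Nc2cc(OCCNC(=O)OC(C)(C)C)cc3cccnc23)cn1` repeats the same change on compound 3: methyl in place of hydrogen on an aromatic carbon. Because the earlier step that the two limits leave unreadable from compound 2 to compound 1 gave no readable size, the methyl is expected to shift little, and compound 4 is estimated to land close to compound 3, a step of a 1.1-fold lower number from compound 3 to compound 4 (0.02 log units; within the scatter). Compound 4 is therefore expected near 9000 nM, between 4000 nM and 20000 nM, with a fair chance that this assay again reports only a limit.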

Compound 4, half-maximal inhibitory concentration: 2170 nM
Compound 4: the middle estimate sits 4.1-fold (0.62 log units) above what was measured, and the stated range ends above it.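

On the core of the side-chain compounds, the change from pyrazin-2-yl to 5-methylpyrazin-2-yl gives, in this assay, a 4.4-fold lower number from compound 3 to compound 4 (0.64 log units; beyond the scatter), so here the methyl goes with stronger inhibition, and compound 4 gives 2170 nM. This is the only readable size for the change, since the pair on the other core, compound 2 and compound 1, cannot be read: the limit of > 10000 nM in this assay, at which 2 of the 4 values shown sit. The data therefore show that the change can lower the number on one core, but they do not show that it transfers from one core to another, whether its size would match on the core of compound 2, or why the number falls.

Still open, on these data alone, is whether the step depends on the side chain, for example whether it would persist with a free amine at the end of that chain or with a longer chain. As far as these compounds go, it is also open whether an ethyl group in place of the methyl would go further or lose the step.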